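Acetyl in place of the silyl ether on the primary oxygen

This account rests on a few compounds, and the source may have more. Where it says the series, first, only, none or still open, it means among the compounds named here.

Of the compounds shown here, two of the shared core have been measured. In a functional assay on Lu1 cells (Homo sapiens) for cytotoxicity, read by sulforhodamine B assay (on this read-out higher numbers stand for an effect only at larger amounts of compound and lower numbers for an effect already at smaller amounts), compound 1 `C=C1CC[C@@H]2[C@](C)(CO[Si](C)(C)C(C)(C)C)[C@H](O)CC[C@@]2(C)[C@@H]1C/C=C1/C(=O)OC[C@H]1O` gives 48.8 uM. In this assay, among the compounds with values here, compound 2 `C=C1CC[C@@H]2[C@](C)(CO[Si](C(C)C)(C(C)C)C(C)C)[C@H](O)CC[C@@]2(C)[C@@H]1C/C=C1/C(=O)OC[C@H]1O` gives 3.01 uM, the lowest of the two numbers; the only measured step is a 16-fold lower number from compound 1 to compound 2 (1.21 log units; beyond the scatter), where the group on the oxygen on the saturated carbon became larger and the number fell well beyond the scatter.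

Compound 3 `C=C1CC[C@@H]2[C@](C)(COC(C)=O)[C@H](O)CC[C@@]2(C)[C@@H]1C/C=C1/C(=O)OC[C@H]1O` is not yet measured. It differs from compound 2 in one place: a group of 3 heavy atoms (2 carbon, 1 oxygen; no ring) in place of a group of 10 heavy atoms (9 carbon, 1 silicon; no ring), on an oxygen on a saturated carbon. Within the data shown here, the group at this position therefore shrinks again, and to a size below that of either measured compound, so the one measured step points the other way.

Among the measured compounds shown here, because the enlargement in a 16-fold lower number from compound 1 to compound 2 (1.21 log units; beyond the scatter) lowered the number, compound 3 is expected to give a higher number than compound 2, with the size of the step uncertain since no acetyl compound has been measured. For compound 3 the expected step is a 10-fold higher number from compound 2 to compound 3 (1.00 log units; beyond the scatter). Compound 3 is estimated at 30 uM in this assay, with a range from 8 uM to 120 uM.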

Compound 3, concentration for half-maximal effect: 14 uM
The estimate for compound 3 lay 2.1-fold (0.33 log units) above the measured number; the range from low to high includes it.
By their numbers in this assay, from the lowest: compound 2; then compound 3; then compound 1.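

Acetyl on this oxygen keeps much of the effect in this assay even though it is the smallest group of the series: the change gives a 4.7-fold higher number from compound 2 to compound 3 (0.67 log units; beyond the scatter) and so gives back only part of the distance opened by a 16-fold lower number from compound 1 to compound 2 (1.21 log units; beyond the scatter). Against the group of compound 1 the same acetyl gives a 3.5-fold lower number from compound 1 to compound 3 (0.54 log units; beyond the scatter) and so the number does not follow the heavy-atom count of the group at this position: the order by size would put compound 3 at the high end, and compound 1 stands there instead, which breaks the simple reading of the first step as larger group, lower number. The three compounds therefore show that the identity of the group on this oxygen matters as well as its count of heavy atoms, while nothing available bears on why the order falls this way.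

Where a free hydroxyl on this oxygen would fall remains open, and with it whether any group here is needed at all. Also open, from the compounds shown here alone, is whether a longer acyl chain such as hexanoyl, or a benzoyl ester, would bring the ester series down towards compound 2.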